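The source may report more compounds than this note shows. Statements on the series, on what has been measured and on what is new or still open speak of the compounds shown alone.

Measured compounds:
compound 1 `CCOC(=O)N1CCC(Oc2ncnc3c2CCN3c2ccc(S(C)(=O)=O)cc2F)CC1`, 251 nM
compound 2 `CCCOC(=O)N1CCC(Oc2ncnc3c2CCN3c2ccc(S(C)(=O)=O)cc2F)CC1`, 79.4 nM
compound 3 `Cc1nc(OC2CCN(C(=O)OC(C)(C)C)CC2)c2c(n1)N(c1ccc(S(C)(=O)=O)cc1F)CC2`, 126 nM

In a functional assay on CHO-K1 cells for agonist activity at Glucose-dependent insulinotropic receptor (Homo sapiens), read by a luciferase reporter, with a stated time of 5 h (on this read-out lower numbers stand for an effect already at smaller amounts and higher numbers for an effect only at larger amounts of compound), compound 2 gives 79.4 nM and compound 1 gives 251 nM. The two differ by hydrogen in place of methyl on a saturated chain carbon, two bonds along the chain from an oxygen next to a carbonyl group, and the step is a 3.2-fold higher number from compound 2 to compound 1 (0.50 log units; beyond the scatter). Compound 3 has a different core; how its core differs from that of compound 2 is not broken down here. In this assay compound 3 gives 126 nM, which lies within the scatter of the values of both compound 2 and compound 1.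

Compound 4 `Cc1nc(OC2CCN(C(=O)OC(C)C)CC2)c2c(n1)N(c1ccc(S(C)(=O)=O)cc1F)CC2` is not yet measured. It differs from compound 3 by hydrogen in place of methyl on a saturated chain carbon bound to an oxygen next to a carbonyl group and two saturated chain carbons. This is the same kind of change as that from compound 2 to compound 1, but at a different place: there the carbon carrying the change sits two bonds along the chain from an oxygen next to a carbonyl group, here it is bound to that oxygen and to two saturated chain carbons. Because the earlier step was a 3.2-fold higher number from compound 2 to compound 1 (0.50 log units; beyond the scatter), a step in the same direction is expected, so compound 4 is estimated at 250 nM in this assay. The expected step is a 2.0-fold higher number from compound 3 to compound 4 (0.30 log units; within the scatter), with the range 100 nM to 630 nM.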

Compound 4, half-maximal effective concentration: 100 nM
For compound 4 the middle estimate is 2.5-fold (0.40 log units) above the measured one; the measured number falls inside the stated range.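

In this assay, hydrogen in place of methyl on the carbon bound to the oxygen of the carbonyl group gives a 1.3-fold lower number from compound 3 to compound 4 (0.10 log units; within the scatter), so tert-butoxycarbonyl to isopropoxycarbonyl on this core separates compound 3 and compound 4 by no more than the usual scatter. Set beside the earlier step, the change does not carry over from one core to the other as a fixed step: the same change on two cores in this assay, a 3.2-fold higher number (0.50 log units; beyond the scatter) from compound 2 to compound 1 and a 1.3-fold lower number (0.10 log units; within the scatter) from compound 3 to compound 4, 4.0-fold (0.60 log units) apart, beyond the scatter of two such steps This does not show that the core is what sets the two steps apart, since the change also sits at a different place on the chain in each pair and each step rests on a single pair of compounds.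

The compounds shown leave open how isopropoxycarbonyl and tert-butoxycarbonyl behave on the core of compound 1, and how the chain of compound 2 behaves on the core of compound 3, which is what would separate core from place. Also open, as far as these compounds go, is whether a longer chain or an amide in place of the oxygen-linked carbonyl group follows either step.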